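A few compounds are considered here, and "the series" means these few. Any claim that something is new, unique, unknown or untested is made for them only; others in the source may bear on it.

Measured compounds in a physicochemical assay for solubility, read by HPLC, with a stated time of 24 h; on this read-out lower numbers stand for lower solubility and higher numbers for higher solubility:
- compound 1 `O=C1O[C@@H](CN2CCCCC2)CN1c1ccc(-n2cc(-c3ccccn3)cn2)c(F)c1`: 219000 nM
- compound 2 `O=C1CCC(=O)N1C[C@H]1CN(c2ccc(-n3cc(-c4ccccn4)cn3)c(F)c2)C(=O)O1`: 45300 nM
- compound 3 `CC(=O)OC[C@H]1CN(c2ccc(-n3cc(-c4ccccn4)cn3)c(F)c2)C(=O)O1`: 373000 nM

Compound 3 gives the highest number of the three in this assay. Its nearest neighbour is compound 1, which sits within the scatter of it; compound 2 lies well apart, as shown by an 8.2-fold higher number from compound 2 to compound 3 (0.92 log units; beyond the scatter). The step of a 1.7-fold higher number from compound 1 to compound 3 (0.23 log units; within the scatter) shows that exchanging the group on the saturated chain carbon bound to a saturated ring carbon need not move the number beyond the scatter, while a 4.8-fold lower number from compound 1 to compound 2 (0.68 log units; beyond the scatter) and an 8.2-fold higher number from compound 2 to compound 3 (0.92 log units; beyond the scatter) show that it can, in the modest range.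

Compound 4 `O=C1O[C@@H](Cn2ccnc2)CN1c1ccc(-n2cc(-c3ccccn3)cn2)c(F)c1` is the next member of the series at the same position. The change from compound 3 is 1H-imidazol-1-yl in place of acetoxy on a saturated chain carbon bound to a saturated ring carbon. The three measured steps all concern this same place, so they bear directly on the expectation, and they span from no change to a modest one. Going by the values given here, nothing measured so far carries the entering ring, so no step involving an aromatic five-membered ring is available for comparison.

The expected step for compound 4 is a 1.9-fold lower number from compound 3 to compound 4 (0.27 log units; within the scatter), a modest lowering that remains short of the size seen in an 8.2-fold higher number from compound 2 to compound 3 (0.92 log units; beyond the scatter). Compound 4 is therefore estimated at 200000 nM in this assay, with a range from 80000 nM to 450000 nM.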

Compound 4, solubility: 12300 nM
For compound 4 the middle estimate is 16-fold (1.21 log units) above the measured one; the measured number lies below the stated range.
By their numbers in this assay, from the lowest: compound 4; then compound 2; then compounds 1 and 3 (each within the scatter of the next).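

In this assay, going by these compounds alone, this place on the saturated chain carbon bound to a saturated ring carbon allows much larger steps than the earlier compounds showed: 1H-imidazol-1-yl gives a 30-fold lower number from compound 3 to compound 4 (1.48 log units; beyond the scatter) and an 18-fold lower number from compound 1 to compound 4 (1.25 log units; beyond the scatter), both large, while the steps among the first three compounds stayed modest or within the scatter. The entering ring also takes the number past that of the lowest earlier member, with a 3.7-fold lower number from compound 2 to compound 4 (0.57 log units; beyond the scatter), so compound 4 now stands lowest of the four, beyond the scatter of every other compound, and one aromatic five-membered ring at this place is enough to set the series' lower end. No measurement shown accounts for the size of these steps.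

On these data alone, whether this low number goes with aromatic five-membered rings in general remains open, since 1H-1,2,4-triazol-1-yl or pyrrol-1-yl at the same place would separate the ring from its particular nitrogen atoms. Also open, as far as these compounds go, is where an open-chain amine such as dimethylamino, a hydroxyl or a carboxylic acid on this chain carbon would fall relative to compound 4 and compound 2.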